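Ring Size at the Chain End: Compound 2 to Compound 3

The source may hold more compounds than are shown below. What is called first, only, known or untested is meant among the compounds shown, and "the series" means these compounds.

Of the compounds shown here, two from one series have been measured in a functional assay on U-87MG ATCC cells (Homo sapiens) for inhibition, read by MTT assay, with a stated time of 72 h; a higher number here means a weaker inhibitor, a lower number a stronger inhibitor. Compound 1, `COc1cc2c(Oc3ccc(NC(=O)c4nn(-c5ccccc5OC(F)(F)F)c(=O)cc4C)cc3F)ccnc2cc1OCCCN1CCCCC1`, gives 1300 nM in this assay. Compound 2, `COc1ccc(-n2nc(C(=O)Nc3ccc(Oc4ccnc5cc(OCCCN6CCCC6)c(OC)cc45)c(F)c3)c(C)cc2=O)cc1`, gives 2960 nM, the higher of the two numbers, and the gap down to compound 1 is beyond the usual scatter. Compound 3, `COc1ccc(-n2nc(C(=O)Nc3ccc(Oc4ccnc5cc(OCCCN6CCCCC6)c(OC)cc45)c(F)c3)c(C)cc2=O)cc1`, has not yet been measured. It differs from compound 2 in one place: piperidin-1-yl in place of pyrrolidin-1-yl on a saturated chain carbon, three bonds along the chain from an oxygen on an aromatic ring. Compound 1 also carries the piperidin-1-yl group, but it differs from compound 3 elsewhere as well, so no clean comparison for this single change exists among the measured compounds. The change is a modest one, and the step expected in this assay lies within the usual scatter, perhaps leaning slightly toward a stronger inhibitor: a 1.5-fold lower number from compound 2 to compound 3 (0.17 log units; within the scatter). Compound 3 is therefore estimated at 2000 nM, with a plausible range from 800 nM to 5000 nM.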

Compound 3, half-maximal inhibitory concentration: 1800 nM
The estimate for compound 3 lay 1.1-fold (0.05 log units) above the measured number; low and high end bracket the measured number.
By their numbers in this assay, from the lowest: compounds 1, 3 and 2 (each within the scatter of the next, the first and the last beyond it).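

In this assay, piperidin-1-yl in place of pyrrolidin-1-yl at the end of the propyl chain gives a 1.6-fold lower number from compound 2 to compound 3 (0.22 log units; within the scatter), so this one-carbon growth of the ring produces no difference that can be told apart from assay noise. The group on the aromatic nitrogen can also go from 2-(trifluoromethoxy)phenyl to 4-methoxyphenyl, with a 1.4-fold higher number from compound 1 to compound 3 (0.14 log units; within the scatter) as the result, so this exchange too stays inside the noise. No supporting measurement is available to explain either result.

From the compounds shown here alone, it remains open whether a morpholin-4-yl or dimethylamino group at the end of the chain would shift the number beyond the scatter. The same question stands for a butyl chain carrying the piperidin-1-yl group.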